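Removing the Methoxy Group from a Quinoline Carboxamide

The compounds below may be only part of what the source reports. "The series", "measured", "known", "first", "only" and "open" are said of these compounds alone.

Measured so far:
compound 1, `Cc1c(C(=O)Nc2ccc(-c3ccccc3)cc2)nc2ccccc2c1O`, 46.2%
compound 2, `COc1ccc2nc(C(=O)Nc3ccc(-c4ccccc4)cc3)c(C)c(C(=O)O)c2c1`, 33.6%

Of the compounds shown here, two have been tested in a functional assay on Hep 3B2 cells (Homo sapiens) for antiproliferative activity, read by MTT assay, with a stated time of 24 h, tested at 33.33 ug/mL; a lower number here means a weaker effect, a higher number a stronger effect of the compound at the concentration tested. Compound 1, with structure `Cc1c(C(=O)Nc2ccc(-c3ccccc3)cc2)nc2ccccc2c1O`, gives 46.2% in this assay. Compound 2, with structure `COc1ccc2nc(C(=O)Nc3ccc(-c4ccccc4)cc3)c(C)c(C(=O)O)c2c1`, gives 33.6% in this assay, which is the lower of the two numbers; the gap to compound 1 lies beyond the usual scatter of repeated measurements, so compound 2 shows the weaker effect of the pair.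

The next compound, compound 3, has structure `Cc1c(C(=O)Nc2ccc(-c3ccccc3)cc2)nc2ccccc2c1C(=O)O` and has not yet been tested. It is derived from compound 2 by one change: hydrogen in place of methoxy on an aromatic carbon. Within the data shown here, no step between measured compounds with such a change is available, so the direction of any effect cannot be read from the numbers already in hand.

Given the small size of the change, compound 3 is expected to show a step of a number 2.4 percentage points higher from compound 2 to compound 3 (within the scatter) that stays within the scatter. The estimate for compound 3 in this assay is therefore 36%, with a range from 22% to 52%.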

Compound 3, a percentage reported as inhibition, at one concentration (the size of the read-out at that concentration, not a potency): 11.3%
For compound 3 the middle estimate is 24.7 percentage points above the measured one; the measured number lies below the stated range.
By their numbers in this assay, from the lowest: compound 3; then compound 2; then compound 1.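

Removing the methoxy group from the aromatic carbon of the six-membered aromatic ring of carbon only is not a negligible change in this assay: hydrogen in its place gives a number 22.3 percentage points lower from compound 2 to compound 3 (beyond the scatter), so with the carboxy group present, the read-out depends on what this position carries. The second comparison concerns a different place, where carboxy in place of hydroxy on an aromatic carbon gives a number 34.9 percentage points lower from compound 1 to compound 3 (beyond the scatter), which leaves compound 3 with the lowest number of the three and shows that, without the methoxy group, the hydroxy compound holds the clear advantage over the carboxy compound. No measurement at hand explains either step.

The compounds shown leave open whether the methoxy effect depends on its partner, since they include no compound carrying methoxy together with hydroxy on the shared core. They also leave open whether a chlorine atom, an ethoxy group or an amine at the methoxy position would give a number like that of compound 2 or one closer to that of compound 3.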